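Swapping an Amidine for an Amide on the Pyridine Ring

The source may hold more compounds than are shown below. What is called first, only, known or untested is meant among the compounds shown, and "the series" means these compounds.

Of the compounds shown here, three have been tested in a functional assay for antagonist activity at C-X-C chemokine receptor type 3 (Homo sapiens); on this read-out higher numbers stand for weaker inhibition and lower numbers for stronger inhibition. Compound 3, `CCNC(=N)c1cnc(N2CCN(C3CCN(Cc4ccc(Cl)cc4)CC3)[C@@H](C)C2)c(Cl)c1`, gives 83 nM, the lowest of the three numbers. Compound 2, `O=C(NCc1ccc(F)c(F)c1)c1cnc(N2CCN(C3CCN(Cc4ccc(Cl)cc4)CC3)C(=O)C2)c(Cl)c1`, gives 1400 nM, and compound 1, `CNC(=O)c1cnc(N2CCN(C3CCN(Cc4ccco4)CC3)[C@@H](C)C2)c(Cl)c1`, gives 8100 nM; both gaps from compound 3 lie well beyond the usual scatter, so compound 3 stands as the strongest inhibitor among the measured set.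

Compound 4, `CCNC(=O)c1cnc(N2CCN(C3CCN(Cc4ccc(Cl)cc4)CC3)[C@@H](C)C2)c(Cl)c1`, has not yet been measured. It differs from compound 3 in one place: a group of 5 heavy atoms (3 carbon, 1 nitrogen, 1 oxygen; no ring) in place of a group of 5 heavy atoms (3 carbon, 2 nitrogen; no ring), on an aromatic carbon, giving the ethylcarbamoyl group in place of the amidine-like group. Among the compounds with values here, no measured pair shows this exact change, so there is no directly comparable step. Compound 1 also carries a carbamoyl group and gives a high number, but it differs from compound 4 in two further places, so it serves only as a loose pointer.

The expectation is that this change weakens inhibition in this assay by a step of a 12-fold higher number from compound 3 to compound 4 (1.08 log units; beyond the scatter), beyond the scatter. Compound 4 is therefore estimated at 1000 nM, with a likely range from 200 nM to 5000 nM.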

Compound 4, half-maximal inhibitory concentration: 2.3 nM
The estimate for compound 4 lay 430-fold (2.64 log units) above the measured number, and the stated range ends above it.
By their numbers in this assay, from the lowest: compound 4; then compound 3; then compound 2; then compound 1.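

In this assay the ethylcarbamoyl group in place of the amidine-like group gives a 36-fold lower number from compound 3 to compound 4 (1.56 log units; beyond the scatter) at this position, two atoms from the ring nitrogen and with the rest of the molecule unchanged. Within the data shown here, this is the first comparison here in which only one place differs, and it shows that exchanging one nitrogen of that group for an oxygen can shift the number far beyond the scatter. It also shows that a carbamoyl group at this position can go with strong inhibition on this core, and no measurement shown explains the size of the step.

Going by these compounds, what remains open is whether the ethyl chain itself contributes, since a methyl or propyl on the amide nitrogen would test this. A carboxylic acid or a nitrile at the same position would show how much other groups there change the number.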